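Shifting the aryl substituent on the piperazine ring

The source may report more compounds than this note shows. Statements on the series, on what has been measured and on what is new or still open speak of the compounds shown alone.

Measured compounds:
- compound 1, `O=C(CCCN1CCN(c2ccccc2Cl)CC1)Nc1ccc(Cl)cc1`, 60.5%
- compound 2, `O=C(CCCN1CCN(c2ccc(Cl)cc2)CC1)Nc1ccc(Cl)cc1`, 94.6%

Compound 2 stands highest of the two numbers measured in an assay on HEK293 cells for inhibition of Voltage-dependent T-type calcium channel subunit alpha-1G (Homo sapiens), read by patch clamp, tested at 10 uM; on this read-out lower numbers stand for less inhibition and higher numbers for more inhibition at the one concentration tested (going by the name of the read-out); its nearest neighbour is compound 1, whose value lies a number 34.1 percentage points higher from compound 1 to compound 2 (beyond the scatter). Among the compounds with values here, that single step, in which a 4-chlorophenyl takes the place of a 2-chlorophenyl on an amine nitrogen in a ring, is the only measured change, and it is large and beyond the scatter.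

Compound 3, `COc1ccccc1N1CCN(CCCC(=O)Nc2ccc(Cl)cc2)CC1`, has not yet been measured in this assay. Its difference from compound 2 is 2-methoxyphenyl in place of 4-chlorophenyl on an amine nitrogen in a ring.

The step from compound 1 to compound 2 bears on this change in part: it shows that a 2-chlorophenyl on the ring nitrogen gives markedly less inhibition than a 4-chlorophenyl. Within the data shown here, no measured step shows what a methoxy group does in place of a chlorine, so that part of the change is unknown. On this basis compound 3 is expected to fall below compound 2, with a step of about a number 34.6 percentage points lower from compound 2 to compound 3 (beyond the scatter). The estimate for compound 3 is therefore 60%, with a range from 35% to 85%.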

Compound 3, a percentage reported as inhibition, at one concentration (the size of the read-out at that concentration, not a potency): 84.3%
The estimate for compound 3 lay 24.3 percentage points below the measured number, within the range that was stated.
By their numbers in this assay, from the lowest: compound 1; then compound 3; then compound 2.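

Compound 3 shows that a substituted phenyl of this kind on the amine nitrogen need not give inhibition as low as that of compound 1: in this assay, methoxy in place of chloro on an aromatic carbon gives a number 23.8 percentage points higher from compound 1 to compound 3 (beyond the scatter). This recovers much of the ground between compound 1 and compound 2. Within the data shown here, the 2-methoxyphenyl still does not match the 4-chlorophenyl, with a number 10.3 percentage points lower from compound 2 to compound 3 (beyond the scatter) as a modest step, beyond the scatter, and much smaller than the one printed for the change from 2-chlorophenyl. Among these three compounds, then, the outcome at this place depends on which group the phenyl carries as well as on how the phenyl is substituted, while compound 2 remains the highest.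

The compounds shown leave open whether a 4-methoxyphenyl would reach the level of compound 2, since methoxy and chloro are compared here only as 2-methoxyphenyl and 2-chlorophenyl. They also leave open what a 2-ethoxyphenyl or a 2-fluorophenyl would give at the same place. Nothing available explains the difference between the chloro and methoxy compounds.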